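Volume of Distribution: Trimming the Amide Side Chain

A few compounds are considered here, and "the series" means these few. Any claim that something is new, unique, unknown or untested is made for them only; others in the source may bear on it.

Compound 1 `CCn1c(-c2cnc(C)nc2)nc2c(N[C@H]3CCN(C(=O)C4CCC4)C3)ncnc21`: 0.5 L/kg in an ADME assay (Rattus norvegicus, strain Wistar Han) for pharmacokinetics; on this read-out lower numbers stand for narrower distribution and higher numbers for wider distribution into tissues
Compound 2 `CCn1c(-c2cnc(C)nc2)nc2c(N[C@H]3CCN(C(=O)C4CCOC4)C3)ncnc21`: 0.7 L/kg in this assay
Compound 3 `CCn1c(-c2ccc(C(F)(F)F)nc2)nc2c(O[C@H]3CCN(C(=O)c4cocn4)C3)ncnc21`: 0.3 L/kg in this assay

Among these three numbers compound 2 stands highest; compound 1 lies within the scatter of it, while compound 3 lies beyond the scatter below it. Compound 4 `CCC(=O)N1CC[C@H](Nc2ncnc3c2nc(-c2cnc(C)nc2)n3CC)C1` is not yet measured. It differs from compound 2 in one place: ethyl in place of oxolan-3-yl on a carbonyl carbon. Among the measured compounds shown here, only one measured step bears on this change, the exchange of the group on the same carbonyl carbon, which gave a 1.4-fold higher number from compound 1 to compound 2 (0.15 log units; within the scatter). That step stayed within the scatter, so the move to a smaller group on that carbonyl is expected to give no step beyond the scatter, at most a slight fall towards compound 1. Compound 4 is therefore estimated at 0.55 L/kg, within a range from 0.3 L/kg to 1 L/kg, meaning an expected step of a 1.3-fold lower number from compound 2 to compound 4 (0.10 log units; within the scatter).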

Compound 4, volume of distribution: 1 L/kg
Compound 4: the middle estimate sits 1.8-fold (0.26 log units) below what was measured; the measured number falls inside the stated range.
By their numbers in this assay, from the lowest: compounds 3, 1, 2 and 4 (each within the scatter of the next, the first and the last beyond it).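

Cutting the group on this carbonyl carbon down to ethyl, which has no ring and no oxygen, keeps the read-out in this assay within the scatter: the change gives a 1.4-fold higher number from compound 2 to compound 4 (0.15 log units; within the scatter), and ethyl in place of cyclobutyl gives a 2.0-fold higher number from compound 1 to compound 4 (0.30 log units; within the scatter). Across cyclobutyl, oxolan-3-yl and ethyl, then, this position shows no step beyond the scatter, with or without a ring or an oxygen in the group. No measured information explains these steps. Still open, from the compounds shown here alone, is how an amine, a carboxylic acid or a longer chain on this carbonyl carbon would read in this assay.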